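Solubility of a benzylamine series: a fluoro for hydroxy swap

The source may hold more compounds than are shown below. What is called first, only, known or untested is meant among the compounds shown, and "the series" means these compounds.

Compound 1 `COc1cccc(CNCCCNc2ccnc3cc(Oc4ccc(Cl)cc4)ccc23)c1O`: 14500 nM
Compound 2 `COc1cccc(CNCCCNc2ccnc3cc(Oc4ccccc4)ccc23)c1O`: 14500 nM
Compound 3 `COc1ccccc1Oc1ccc2c(NCCCNCc3cccc(OC)c3O)ccnc2c1`: 14500 nM

In a physicochemical assay for solubility, with a stated time of 18 h, at pH 7.4 (a higher number here means a more soluble compound, a lower number a less soluble compound), compound 1 gives 14500 nM and stands level with compounds 2 and 3. The steps of no change at the digits printed from compound 1 to compound 2 (within the scatter) and no change at the digits printed from compound 1 to compound 3 (within the scatter) all lie within the scatter, as does no change at the digits printed from compound 2 to compound 3 (within the scatter). Compound 4 `COc1ccc(F)cc1CNCCCNc1ccnc2cc(Oc3ccc(Cl)cc3)ccc12` differs from compound 1 in another part of the molecule: 5-fluoro-2-methoxyphenyl in place of 2-hydroxy-3-methoxyphenyl on a saturated chain carbon bound to an amine nitrogen. Going by the values given here, none of the measured steps touches this benzyl position, so no measured step bears directly on the change; the measured steps show only that changes on the aryloxy side left this assay unmoved. Compound 4 is therefore expected to give about 12000 nM, within a range of 4000 nM to 30000 nM, a step of a 1.2-fold lower number from compound 1 to compound 4 (0.08 log units; within the scatter) that is expected to remain within the scatter.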

Compound 4, solubility: 14500 nM
Compound 4: the middle estimate sits 1.2-fold (0.08 log units) below what was measured; measured number inside the range.
By their numbers in this assay, from the lowest: compounds 1, 2, 3 and 4 (each within the scatter of the next).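

Going by these compounds alone, the step of no change at the digits printed from compound 1 to compound 4 (within the scatter) gives the first reading at this position in this assay, since the earlier compounds varied only the aryloxy side. Here the whole benzyl aryl group was exchanged, with 0 hydrogen-bond donors in place of 1 and 1 hydrogen-bond acceptor in place of 2, and the printed number held. Nothing shown accounts for this. The compounds shown leave open how the loss of the hydroxy and the entry of the fluoro each count alone. They also leave open whether a carboxylic acid on that ring, or a longer chain, would move the number.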